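A few compounds are considered here, and "the series" means these few. Any claim that something is new, unique, unknown or untested is made for them only; others in the source may bear on it.

Measured so far in a physicochemical assay for solubility, in phosphate buffer, with a stated time of 18 h (a higher number here means a more soluble compound, a lower number a less soluble compound), are three compounds
- Compound 1 `CC(C)(C)c1ccc2c(N)c(C#N)c(N)nc2n1` gives 14200 nM
- Compound 2 `N#Cc1c(N)nc2nc(C3CC3)ncc2c1N` gives 23000 nM
- Compound 3 `N#Cc1c(N)nc2nc(C3CCC3)ncc2c1N` gives 217000 nM

Compound 2 (23000 nM) lies within the usual scatter of compound 1 (14200 nM), so these two numbers cannot be ranked. The number for compound 3 stands clearly higher than both. No single change links compound 1 to compound 2, so only their values can be compared.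

The next compound to be measured is compound 4 `N#Cc1c(N)nc2nc(C3CCCCC3)ncc2c1N`. It keeps the core of compound 2 and changes one group cyclohexyl in place of cyclopropyl on an aromatic carbon in the form of cyclohexyl in place of cyclopropyl on an aromatic carbon, at a position between two ring nitrogen atoms.

Among the measured compounds shown here, only one measured step bears on this change, the swap of cyclopropyl for cyclobutyl at the same place, which gave a 9.4-fold higher number from compound 2 to compound 3 (0.97 log units; beyond the scatter) and counts as modest. That single step points upward, but one step does not make a trend, and nothing measured shows whether it carries on to cyclohexyl. A small rise in this assay is therefore expected, perhaps none beyond the scatter, with real uncertainty in both directions.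

The estimate amounts to an expected 1.7-fold higher number from compound 2 to compound 4 (0.24 log units; within the scatter) in this case. For compound 4 the expected value is 40000 nM (estimated range 5000 nM to 250000 nM).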

Compound 4, solubility: 81000 nM
The estimate for compound 4 lay 2.0-fold (0.31 log units) below the measured number; low and high end bracket the measured number.
By their numbers in this assay, from the lowest: compounds 1 and 2 (each within the scatter of the next); then compound 4; then compound 3.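

In this assay, the rise seen with cyclobutyl at this position, between two ring nitrogen atoms, is not unique to that ring: cyclohexyl also gives a clear gain over cyclopropyl, with a 3.5-fold higher number from compound 2 to compound 4 (0.55 log units; beyond the scatter). The number does not simply keep climbing as the ring grows, however, since going on from cyclobutyl to cyclohexyl gives a 2.7-fold lower number from compound 3 to compound 4 (0.43 log units; beyond the scatter), leaving cyclobutyl highest of the three rings and cyclohexyl in the middle. Nothing available explains why these carbon rings differ in this way.

As far as these compounds go, all three groups compared at this position are non-aromatic rings of carbon only, so it remains open whether a gain over cyclopropyl also comes with an open butyl chain, or with a ring that holds oxygen, such as tetrahydropyranyl. Cyclopentyl also remains an open case, and its number would show whether the fall from cyclobutyl to cyclohexyl is gradual or abrupt.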